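The source may hold more compounds than are shown below. What is called first, only, known or untested is meant among the compounds shown, and "the series" means these compounds.

The step runs from compound 1 `Cc1ccc(C2=Nn3c(Cc4ccc(S(C)(=O)=O)cc4)nnc3SC2)cc1` to compound 3 `CS(=O)(=O)c1ccc(Cc2nnc3n2N=C(c2cc(Cl)sc2Cl)CS3)cc1`, two compounds that share one core and differ in a single group. In a functional assay on HT-29 cells (Homo sapiens) for cytotoxicity, read by MTT assay, with a stated time of 48 h, tested at 12.5 uM (on this read-out higher numbers stand for a stronger effect at the one concentration tested and lower numbers for a weaker effect), compound 1 is reported as "not active" (no number reported), with no number attached, so it stands only as a compound without a measurable effect in this test. A third compound, compound 2 `CS(=O)(=O)c1ccc(Cc2nnc3n2N=C(c2cc4ccccc4c(=O)o2)CS3)cc1`, carries another group at the same place, and in this assay compound 2 gives 22.4%, which shows that a change of the group at this position can bring a modest effect. The change to compound 3 is 2,5-dichlorothiophen-3-yl in place of 4-methylphenyl on a carbon with a double bond to nitrogen. For the measured compounds named here, no measured step links compound 1 and compound 3, so the size of the change cannot be read from any pair; the expectation is a small rise in this assay, guided by the fact that compound 2 gives 22.4% with a different group in the same place, and possibly no rise beyond the scatter. For compound 3 the activity in this assay is estimated at 15%, within a range from 0% to 35%.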

Compound 3, a percentage reported as activity, at one concentration (the size of the read-out at that concentration, not a potency): "not active" (no number reported)
Nothing numeric was reported for compound 3; no gap can be computed for the estimate.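

In this assay, for the compounds shown here, compound 1 gives "not active" (no number reported) and compound 3 gives "not active" (no number reported), so no step between these two compounds can be read. The compounds shown leave open whether replacing 4-methylphenyl with 2,5-dichlorothiophen-3-yl changes the effect on these cells at all. No available evidence bears on this result.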